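Methyl in place of hydrogen on the distal ring of compound 1

The source may report more compounds than this note shows. Statements on the series, on what has been measured and on what is new or still open speak of the compounds shown alone.

Compound 1 `OCCCCCC(O)c1ccc(-c2ccccc2)cc1` carries a second ring on its core. In a functional assay on J774 cells (Mus musculus) for cytotoxicity, read by resazurin assay (on this read-out higher numbers stand for weaker inhibition and lower numbers for stronger inhibition), compound 1 gives 22000 nM, the highest of the three numbers here, though its neighbours sit within the usual scatter. Compound 2 `OCCCCCC(O)c1ccc(-c2ccc(Br)cc2)cc1` gives 20000 nM and compound 3 `OCCCCCC(O)c1ccc(-c2ccc(F)cc2)cc1` gives 18000 nM. The steps of a 1.1-fold lower number from compound 1 to compound 2 (0.04 log units; within the scatter) and a 1.2-fold lower number from compound 1 to compound 3 (0.09 log units; within the scatter) show that placing a halogen on this ring leaves the read-out essentially unchanged. Compound 4 `Cc1ccccc1-c1ccc(C(O)CCCCCO)cc1` differs from compound 1 by methyl in place of hydrogen on an aromatic carbon, on an aromatic carbon ortho to a large group. Since both earlier substitutions on this ring stayed within the scatter, a step of a 1.1-fold lower number from compound 1 to compound 4 (0.04 log units; within the scatter) is expected, meaning no change beyond the scatter. Compound 4 is therefore estimated at 20000 nM, within 10000 nM to 40000 nM.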

Compound 4, half-maximal inhibitory concentration: 24000 nM
Compound 4: middle estimate off by 1.2-fold (0.08 log units), on the low side, and the stated range covers the measured number.
By their numbers in this assay, from the lowest: compounds 3, 2, 1 and 4 (each within the scatter of the next).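

In this assay, methyl on an aromatic carbon ortho to a large group gives a 1.1-fold higher number from compound 1 to compound 4 (0.04 log units; within the scatter), so a carbon group at this position leaves the number as flat as the halogens did on this ring. The comparisons with the halogen compounds agree, with a 1.3-fold higher number from compound 3 to compound 4 (0.12 log units; within the scatter) and a 1.2-fold higher number from compound 2 to compound 4 (0.08 log units; within the scatter) still inside the scatter. No measurement given here explains this flatness. On these data alone, whether an amine or a carboxylic acid on this ring would move the number beyond the scatter stays open.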